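The source may report more compounds than this note shows. Statements on the series, on what has been measured and on what is new or still open speak of the compounds shown alone.

Measured in a functional assay on A549 cells (Homo sapiens) for antiproliferative activity, read by spectrophotometry, with a stated time of 2 days; a higher number here means a weaker inhibitor of growth, a lower number a stronger inhibitor of growth:
- compound 1 `COc1ccc(Nc2ncc(C(F)(F)F)c(N3Cc4cccc(N(C)S(C)(=O)=O)c4C3)n2)cc1C(F)(F)F`: > 30000 nM (a limit)
- compound 2 `CN(c1cccc2c1CN(c1nc(Nc3cccc(Oc4ccccc4)c3)ncc1C(F)(F)F)C2)S(C)(=O)=O`: 19000 nM
- compound 3 `COc1cc(Nc2ncc(C(F)(F)F)c(N3Cc4cccc(N(C)S(C)(=O)=O)c4C3)n2)cc(C(F)(F)F)c1`: > 30000 nM (a limit)

In this assay compound 3 gives > 30000 nM, which is a limit and not a number. Going by the values given here, the series so far is dominated by the limit of > 30000 nM in this assay, at which 2 of the 3 values shown sit. Among the compounds with values here, compound 2 is the only one with a number, 19000 nM.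

Compound 4 `CN(c1cccc2c1CN(c1nc(Nc3cccc(C(F)(F)F)c3)ncc1C(F)(F)F)C2)S(C)(=O)=O` follows from compound 3 by one change, hydrogen in place of methoxy on an aromatic carbon, which turns 3-methoxy-5-(trifluoromethyl)phenyl into 3-(trifluoromethyl)phenyl.

Within the data shown here, the only measured step between two compounds that differ in one place is a step that the two limits leave unreadable from compound 1 to compound 3. Among the measured compounds shown here, it moves the substituents on the same ring but gives no size, and no measured step removes the methoxy. With nothing readable to carry over, no direction can be argued, and the expectation in this assay is a small step or none beyond the scatter, with compound 4 staying a weak inhibitor of growth. A further limit reading would be no surprise.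

The estimated step is an at least 1.1-fold lower number from compound 3 to compound 4 (0.06 log units; that floor lies within the scatter).

For compound 4 the expected value is 26000 nM, with an estimated range from 10000 nM to 45000 nM.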

Compound 4, concentration for 50% growth inhibition: > 30000 nM
Compound 4 gave a limit, no number (the forecaster's own chance of this, stated with the estimate: 55%); middle value at least 1.1-fold (0.06 log units) from the limit.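

In this assay compound 4 also gives > 30000 nM, which is a limit and not a number. Going by these compounds, the steps to compound 4 from compound 1 and from compound 3 cannot be read, so taking the methoxy off this ring leaves a trifluoromethyl-bearing ring with no number, and the size of that change stays unknown. Going by these compounds alone, the one readable step, trifluoromethyl in place of phenoxy on an aromatic carbon, is an at least 1.5-fold higher number from compound 2 to compound 4 (0.19 log units; that floor lies within the scatter), so the phenoxy of compound 2 cannot yet be separated from the trifluoromethyl of compound 4 with any confidence.

On these data alone, how far any of these ring changes moves growth inhibition remains open, since the readings give almost no numbers to compare: the limit of > 30000 nM in this assay, at which 3 of the 4 values shown sit. Also open, as far as these compounds go, is whether an amine, a carboxylic acid or a longer ether chain in place of the trifluoromethyl on this ring would give a number well clear of that limit in this assay.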